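This account rests on a few compounds, and the source may have more. Where it says the series, first, only, none or still open, it means among the compounds named here.

Measured in a functional assay, read by spectrophotometry, with a stated time of 3 min; on this read-out lower numbers stand for stronger inhibition and higher numbers for weaker inhibition:

- compound 1 `O=c1[nH]c2ccccc2cc1/C=N/O`: 31800 nM
- compound 2 `Cc1ccc2[nH]c(=O)c(/C=N/O)cc2c1`: 38900 nM
- compound 3 `Cc1ccc2[nH]c(=O)c(/C=N/Nc3ccc([N+](=O)[O-])cc3)cc2c1`: 8250 nM

Compound 1 stands at the upper end of these numbers, level with compound 2 within the scatter, while compound 3 has a clearly lower number. The next compound, compound 4 `N/N=C/c1cc2ccccc2[nH]c1=O`, departs from compound 1 by one exchange: amino in place of hydroxy on a double-bonded nitrogen. Among the measured compounds shown here, no measured step makes this exchange. For the measured compounds named here, the only step available, a 1.2-fold higher number from compound 1 to compound 2 (0.09 log units; within the scatter), is methyl in place of hydrogen on an aromatic carbon, so it shows that the numbers held within the scatter for a different change and gives no direct size for this one. Compound 3, at 8250 nM, shows that a lower number is possible among these compounds, but no step ties it to compound 1. In this assay, no shift beyond the scatter is therefore expected, though the uncertainty is wide. The expected change is a 1.1-fold lower number from compound 1 to compound 4 (0.06 log units; within the scatter). Compound 4 is estimated at 28000 nM, with an expected range of 10000 nM to 70000 nM.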

Compound 4, half-maximal inhibitory concentration: 20600 nM
Estimate against measurement, compound 4: 1.4-fold (0.13 log units) above; the range from low to high includes it.
By their numbers in this assay, from the lowest: compound 3; then compounds 4, 1 and 2 (each within the scatter of the next).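

In this assay, among the compounds shown here, amino in place of hydroxy on a double-bonded nitrogen gives a 1.5-fold lower number from compound 1 to compound 4 (0.19 log units; within the scatter), the first direct reading of a change at this position, since the earlier step concerned methyl on an aromatic carbon. The exchange swaps one heavy atom for one heavy atom with the same computed counts of hydrogen-bond donors and acceptors and no net charge, and the number stays within the scatter. Nothing available here gives a cause for this result.

The compounds shown leave open how a methoxy or a dimethylamino group on this nitrogen would read in this assay. They also leave open whether the same exchange would stay within the scatter on the methyl-bearing core of compound 2.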